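From methyl to chloro on the shared core

This account rests on a few compounds, and the source may have more. Where it says the series, first, only, none or still open, it means among the compounds named here.

In a functional assay on MCF7 cells (Homo sapiens) for cytotoxicity, read by WST assay, with a stated time of 72 h (a higher number here means a weaker inhibitor, a lower number a stronger inhibitor), compound 1 `O=C1Nc2c(ccc(F)c2F)C1(c1ccccc1)c1ccc(O)cc1` gives 7.1 nM and compound 2 `O=C1Nc2c(ccc(F)c2F)C1(c1ccc(O)cc1)C1CCCC1` gives 12 nM. Compound 3 `Cc1ccc2c(c1C)NC(=O)C2(c1ccc(O)cc1)C1CCCCCC1` gives 19 nM, the highest number of the three, clearly above compound 1 but within the scatter of compound 2. Compound 4 `Cc1c(Cl)ccc2c1NC(=O)C2(c1ccc(O)cc1)C1CCCCCC1` departs from compound 3 by one change, chloro in place of methyl on an aromatic carbon. Within the data shown here, no measured step makes this exchange. Among the measured compounds shown here, the only measured step, a 1.7-fold higher number from compound 1 to compound 2 (0.23 log units; within the scatter), lies at another place in the structure and offers just indirect guidance. In this assay, the expected change is therefore none beyond the scatter, with an estimated step of a 1.2-fold lower number from compound 3 to compound 4 (0.07 log units; within the scatter). The estimate for compound 4 is 16 nM, with an expected range from 7 nM to 38 nM.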

Compound 4, half-maximal inhibitory concentration: 51 nM
Compound 4: the middle estimate sits 3.2-fold (0.50 log units) below what was measured, and the stated range ends below it.
By their numbers in this assay, from the lowest: compounds 1, 2 and 3 (each within the scatter of the next, the first and the last beyond it); then compound 4.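

Chloro in place of methyl at this aromatic carbon, ortho to a methyl group, is not a neutral exchange in this assay: it gives a 2.7-fold higher number from compound 3 to compound 4 (0.43 log units; beyond the scatter) and so raises the number beyond the scatter. The counted features do not separate the two groups, as each has one heavy atom, no hydrogen-bond donor or acceptor and no net charge. Nothing available explains this step.

Going by these compounds, whether bromo, methoxy or an amine at this carbon would keep the number near that of methyl or chloro remains open. Also open, on these data alone, is whether the same exchange would give a similar step in other compounds.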